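Swapping the Amide for a Sulfonamide on the Thiazole Nitrogen

This account rests on a few compounds, and the source may have more. Where it says the series, first, only, none or still open, it means among the compounds named here.

The four compounds share one core and were examined in an ADME assay on HepG2 2.2.15 cells (Homo sapiens) for cytotoxicity; on this read-out higher numbers stand for lower toxicity in this test and lower numbers for higher toxicity in this test. Compound 1 `Cc1cc(Br)cc(OC(c2ccc(Cl)cc2)c2cnc(NC(=O)OC(C)(C)C)s2)c1` gives > 50000 nM, which is a limit of this assay rather than a number. Compound 2 `CC(C)(C)OC(=O)Nc1ncc(C(Oc2ccc3cc(Br)ccc3c2)c2ccc(Cl)cc2)s1` likewise gives > 50000 nM, again a limit. The step that the two limits leave unreadable from compound 1 to compound 2 therefore cannot be read. Compound 3 `O=C(Nc1ncc(C(Oc2ccc3cc(Br)ccc3c2)c2ccc(Cl)cc2)s1)c1ccc(F)cc1` is recorded in this assay as "not toxic" (no number reported), without any number. It thus stands alongside the two earlier results, of which two of the three values shown sit at the limit of > 50000 nM in this assay, at which 2 of the 3 values shown sit. Compound 4 `O=S(=O)(Nc1ncc(C(Oc2ccc3cc(Br)ccc3c2)c2ccc(Cl)cc2)s1)c1cccc2nsnc12` has not yet been measured in this assay. It differs from compound 3 by a group of 12 heavy atoms (6 carbon, 2 nitrogen, 2 oxygen, 2 sulfur; one five-membered aromatic ring with 3 hetero atoms, one six-membered aromatic ring of carbon only) in place of a group of 9 heavy atoms (7 carbon, 1 oxygen, 1 fluorine; one six-membered aromatic ring of carbon only), on a nitrogen on an aromatic ring. Within the data shown here, no measured step bears on this change: the only step available, a step that the two limits leave unreadable from compound 1 to compound 2, concerns a different part of the molecule and its size is not readable, so neither a size nor a direction can be carried over from it. The reading of compound 4 is consequently expected to stay in the same region as compounds 1, 2 and 3, with a considerable chance that only a limit is reported. For compound 4 the estimate in this assay is 60000 nM, within a range from 25000 nM to 150000 nM.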

Compound 4, half-maximal cytotoxic concentration: "not toxic" (no number reported)
Compound 4 has no reported number here, and the estimate cannot be compared.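

In this assay, compound 3 and compound 4 are both recorded as not toxic without a number, so no step can be read between them. The compounds shown leave open whether exchanging the group on the nitrogen changes this read-out at all, as the only other values are limits: the limit of > 50000 nM in this assay, at which 2 of the 4 values shown sit.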